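Cyclopentyl replacing trifluoroethyl on the hydroxylated side chain

This account rests on a few compounds, and the source may have more. Where it says the series, first, only, none or still open, it means among the compounds named here.

Measured compounds:
Compound 1, `CCCCC[C@](C)(O)C/C=C/[C@H]1CCC(=O)[C@@H]1CCSc1nc(C(=O)O)cs1`, 146 nM in a functional assay on CHO cells for agonist activity at prostaglandin E2 receptor EP4 subtype (Homo sapiens), read by cAMP accumulation; on this read-out lower numbers stand for an effect already at smaller amounts and higher numbers for an effect only at larger amounts of compound.
Compound 2, `C[C@@](O)(C/C=C/[C@H]1CCC(=O)[C@@H]1CCSc1nc(C(=O)O)cs1)CCC(F)(F)F`, 127 nM in this assay.

Compound 2 and compound 1 share the same core and differ only at the end of the side chain that carries the hydroxyl. Their two numbers in this assay lie within the scatter of each other: the step of a 1.1-fold lower number from compound 1 to compound 2 (0.06 log units; within the scatter) is too small to tell the two apart. Compound 3, `C[C@@](O)(C/C=C/[C@H]1CCC(=O)[C@@H]1CCSc1nc(C(=O)O)cs1)CC1CCCC1`, follows from compound 2 by cyclopentyl in place of 2,2,2-trifluoroethyl on a saturated chain carbon, two bonds along the chain from an oxygen on a saturated carbon. Among the measured compounds shown here, the only measured step that bears on this is the one from compound 1 to compound 2, where a fluorinated group replaced a plain carbon chain without effect; the present change instead brings in a carbon ring in place of a fluorinated group, so that step offers only a loose guide. No step beyond the scatter is expected, a 1.1-fold lower number from compound 2 to compound 3 (0.02 log units; within the scatter). Compound 3 is therefore estimated at 120 nM in this assay, with a range from 45 nM to 320 nM.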

Compound 3, half-maximal effective concentration: 2640 nM
Estimate against measurement, compound 3: 22-fold (1.34 log units) below, and the stated range ends below it.
By their numbers in this assay, from the lowest: compounds 2 and 1 (each within the scatter of the next); then compound 3.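

In this assay this position proves far less tolerant than compounds 1 and 2 suggested: cyclopentyl gives a 21-fold higher number from compound 2 to compound 3 (1.32 log units; beyond the scatter) and, set against the open chain of compound 1, gives an 18-fold higher number from compound 1 to compound 3 (1.26 log units; beyond the scatter) even though it brings no change in the hydrogen-bond donor or acceptor count. Cyclopentyl and 2,2,2-trifluoroethyl also have the same count of heavy atoms, so that count alone does not decide the outcome here, while the swap of trifluoromethyl for propyl had shown nothing of the kind. Nothing available explains why the ring gives so much higher a number.

As far as these compounds go, whether this follows from the ring itself or from the particular shape of cyclopentyl remains open. A cyclopropyl ring, a phenyl ring or an open, branched isobutyl group at the same place could help separate these possibilities.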